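Benzylsulfanyl replacing 3-methoxypropoxy on the pyridine-type core

The source may hold more compounds than are shown below. What is called first, only, known or untested is meant among the compounds shown, and "the series" means these compounds.

Compound 3 `COCCCOc1nc(C(C)(C)C)ccc1CNC(=O)C(C)c1ccc(NS(C)(=O)=O)c(F)c1` sits second highest of the three measured numbers in an assay on cells for antagonist activity at transient receptor potential cation channel subfamily V member 1 (Homo sapiens), read by FLIPR and calcium flux, with a stated time of 6 min (a higher number here means a weaker inhibitor, a lower number a stronger inhibitor), giving 5.6 nM; its nearest neighbour is compound 1 `CCCN(CCC)c1nc(C(C)(C)C)ccc1CNC(=O)C(C)c1ccc(NS(C)(=O)=O)c(F)c1` with 2.5 nM, and the step of a 2.2-fold higher number from compound 1 to compound 3 (0.35 log units; beyond the scatter) is modest. Compound 2 `CCOc1nc(C(C)(C)C)ccc1CNC(=O)C(C)c1ccc(NS(C)(=O)=O)c(F)c1` gives 14.8 nM, and a 2.6-fold lower number from compound 2 to compound 3 (0.42 log units; beyond the scatter) shows that lengthening the alkoxy chain helped. Compound 4 `CC(C(=O)NCc1ccc(C(C)(C)C)nc1SCc1ccccc1)c1ccc(NS(C)(=O)=O)c(F)c1` differs from compound 3 in one place: benzylsulfanyl in place of 3-methoxypropoxy on an aromatic carbon. Going by the values given here, no measured step covers a sulfur-linked or ring-bearing substituent at this position, so the closest guides are a 2.2-fold higher number from compound 1 to compound 3 (0.35 log units; beyond the scatter) and a 5.9-fold higher number from compound 1 to compound 2 (0.77 log units; beyond the scatter), both modest, suggesting this position tolerates variation. The step of a 1.1-fold lower number from compound 3 to compound 4 (0.05 log units; within the scatter) is therefore expected to stay near the scatter. Compound 4 is estimated at 5 nM, with a range of 1.5 nM to 20 nM.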

Compound 4, inhibition constant: 4 nM
The estimate for compound 4 lay 1.3-fold (0.10 log units) above the measured number; the range from low to high includes it.
By their numbers in this assay, from the lowest: compounds 1, 4 and 3 (each within the scatter of the next, the first and the last beyond it); then compound 2.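

Benzylsulfanyl is the only sulfur-linked, ring-bearing group shown at this position, and both a 1.4-fold lower number from compound 3 to compound 4 (0.15 log units; within the scatter) and a 1.6-fold higher number from compound 1 to compound 4 (0.20 log units; within the scatter) remain within the scatter. Ethoxy alone separates from it, with a 3.7-fold lower number from compound 2 to compound 4 (0.57 log units; beyond the scatter) beyond the scatter, so a six-membered aromatic ring of carbon only is accepted on this aromatic carbon next to the ring nitrogen. No evidence available here accounts for this result. The sulfur link and the ring remain unseparated: benzyloxy and benzylamino would test the link, methylsulfanyl the ring. As far as these compounds go, whether a carboxylic acid or a primary amine on the chain is accepted also stays open.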